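Adding a diethylamino group to a sodium/hydrogen exchanger inhibitor

The source may report more compounds than this note shows. Statements on the series, on what has been measured and on what is new or still open speak of the compounds shown alone.

Among the compounds with values here, compound 2 `Cc1cc(Br)c(S(C)(=O)=O)cc1C(=O)N=C(N)N` is the stronger of the two compounds measured so far: in a functional assay for inhibition of sodium/hydrogen exchanger (Oryctolagus cuniculus) (a lower number here means a stronger inhibitor, a higher number a weaker inhibitor), compound 2 gives 12 nM, whereas compound 1 `Cc1cc(Cl)c(S(C)(=O)=O)cc1C(=O)N=C(N)N` gives 25 nM. Within the data shown here, the single measured step, a 2.1-fold lower number from compound 1 to compound 2 (0.32 log units; beyond the scatter), concerns a bromo in place of chloro on an aromatic carbon. Compound 3 `CCN(CC)Cc1cc(Br)c(S(C)(=O)=O)cc1C(=O)N=C(N)N` keeps the bromo and differs from compound 2 only by diethylamino in place of hydrogen on a saturated chain carbon bound to an aromatic carbon. Among the measured compounds shown here, no measured step touches this part of the shared core, so the halogen step gives no guidance on what the new group does. For the measured compounds named here, with no comparable step on record, the expected change from compound 2 to compound 3 is set near zero and is estimated as a 2.5-fold higher number from compound 2 to compound 3 (0.40 log units; beyond the scatter), with a wide range. Compound 3 is therefore expected to give about 30 nM in this assay, somewhere between 8 nM and 120 nM.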

Compound 3, half-maximal inhibitory concentration: 9500 nM
Compound 3: middle estimate off by 320-fold (2.50 log units), on the low side; measured number above the stated range.
By their numbers in this assay, from the lowest: compound 2; then compound 1; then compound 3.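

In this assay, the saturated chain carbon bound to an aromatic carbon proves highly sensitive to change: diethylamino in place of hydrogen there gives a 790-fold higher number from compound 2 to compound 3 (2.90 log units; beyond the scatter), a far larger step than the halogen change, which gave a 2.1-fold lower number from compound 1 to compound 2 (0.32 log units; beyond the scatter). The change from methyl to (diethylamino)methyl therefore shows that this position does not accept every group, something the halogen step, made elsewhere on the shared core, could not reveal. No measurement on hand explains why the number rises so sharply.

As far as these compounds go, whether the loss belongs to diethylamino in particular stays open, as a dimethylamino group, a hydroxy group or a plain propyl chain on the same carbon could each give a different number. From the compounds shown here alone, it is also open whether the step would be as large with chloro in place of bromo.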